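A few compounds are considered here, and "the series" means these few. Any claim that something is new, unique, unknown or untested is made for them only; others in the source may bear on it.

Going by the values given here, in a physicochemical assay for lipophilicity, measured as octanol-water partition (on this read-out lower numbers stand for lower lipophilicity and higher numbers for higher lipophilicity), compound 1 (`CC1=C(C(=O)OCc2ccccn2)C(c2cccc(O)c2)C2=C(CCCC2=O)N1`) gives 1.58 and compound 2 (`CC1=C(C(=O)OCc2ccccn2)C(c2ccco2)C2=C(CCCC2=O)N1`) gives 1.4 on the shared core, so compound 2 stands within the scatter of the only other measured number. Compound 3 (`CC1=C(C(=O)OCc2ccccn2)C(c2ccc(C#N)cc2)C2=C(CCCC2=O)N1`) differs from compound 2 in one place (4-cyanophenyl in place of furan-2-yl on a saturated ring carbon) and carries 4-cyanophenyl in place of furan-2-yl on a saturated ring carbon. Among the compounds with values here, one measured step bears on this change at the same kind of carbon (a number 0.18 log units lower from compound 1 to compound 2 (within the scatter)) and it involves furan-2-yl and 3-hydroxyphenyl. That step contains no 4-cyanophenyl, so it is only a loose guide. A small rise in this assay is expected, about at the edge of the scatter. The expected change is a number 0.30 log units higher from compound 2 to compound 3 (within the scatter) on this single precedent. Compound 3 is estimated at 1.7 (expected range 1.3 to 2.1) for now.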

Compound 3, partition coefficient: 1.73
The estimate for compound 3 lay 0.03 log units below the measured number, within the range that was stated.
By their numbers in this assay, from the lowest: compounds 2, 1 and 3 (each within the scatter of the next, the first and the last beyond it).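

In this assay, the saturated ring carbon of the shared core now gives its first step beyond the scatter: 4-cyanophenyl in place of furan-2-yl gives a number 0.33 log units higher from compound 2 to compound 3 (beyond the scatter). The same group in place of 3-hydroxyphenyl gives a number 0.15 log units higher from compound 1 to compound 3 (within the scatter), so only the furan-2-yl and 4-cyanophenyl pair is separated at this position, and by a modest step. Nothing available accounts for that step.

The change swaps a five-membered aromatic ring with 1 hetero atom for a six-membered carbon-only ring and also brings in a nitrile, and these two parts cannot be told apart on the compounds shown. On these data alone, a plain phenyl would separate them, while the reading in this assay of a carboxylic acid or a primary amine at this carbon remains open.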